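The source may report more compounds than this note shows. Statements on the series, on what has been measured and on what is new or still open speak of the compounds shown alone.

In an ADME assay on MDBK cells (Bos taurus) for cytotoxicity, read by MTT assay, with a stated time of 96 h (a lower number here means that less compound is tolerated, a higher number that more compound is tolerated), compound 2 `O=[N+]([O-])c1ccc(NC(=S)Nc2cccc(C(F)(F)F)c2)cc1` gives 10000 nM and compound 3 `Cc1ccc(NC(=S)Nc2cccc(C(F)(F)F)c2)cc1Cl` gives 10000 nM, so the two stand level within the scatter. Compound 1 `O=C(NC(=S)Nc1cccc(C(F)(F)F)c1)c1ccccc1` gives only a limit and not a number, > 100000 nM. The remaining reference for the series is the limit of > 100000 nM in this assay, at which 1 of the 3 values shown sits.

Compound 4 `FC(F)(F)c1cccc(NC(=S)Nc2ccccc2)c1` differs from compound 2 by one change, hydrogen in place of nitro on an aromatic carbon. Within the data shown here, no step between measured compounds is available, so the expectation rests on the three values alone. Compound 3 at 10000 nM has different groups on that ring from compound 2, yet shows the same value, which speaks against a very large step. Compound 1 leaves room on the tolerated side, with its limit of > 100000 nM. A moderate step towards more compound tolerated is therefore expected in this assay, although a result within the scatter of compound 2 remains possible. The estimated change is a 2.5-fold higher number from compound 2 to compound 4 (0.40 log units; beyond the scatter). Compound 4 is expected at 25000 nM, with an estimated range of 8000 nM to 90000 nM.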

Compound 4, half-maximal cytotoxic concentration: 49000 nM
Estimate against measurement, compound 4: 2.0-fold (0.29 log units) below; the measured number falls inside the stated range.
By their numbers in this assay, from the lowest: compounds 2 and 3 (each within the scatter of the next); then compound 4. At a limit, above all of these: compound 1.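

In this assay, hydrogen in place of nitro on the aromatic carbon para to a large group gives a 4.9-fold higher number from compound 2 to compound 4 (0.69 log units; beyond the scatter). Among these compounds, this is the first pair that differs in one place, and it shows that this position bears on how much compound is tolerated, with the nitro compound on the less tolerated side. Compound 1 still gives a limit and not a number: the limit of > 100000 nM in this assay, at which 1 of the 4 values shown sits.

On these data alone, whether the step belongs to nitro in particular or to any group at this position stays open; a nitrile, an amine or a carboxylic acid on the same carbon would separate the two readings. What lies behind the step also stays open, as the compounds shown come with no measured property that accounts for it.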